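Replacing the 4-aminocyclohexyl group of compound 1

The source may report more compounds than this note shows. Statements on the series, on what has been measured and on what is new or still open speak of the compounds shown alone.

In a functional assay on G-361 cells (Homo sapiens) for inhibition, with a stated time of 72 h (on this read-out lower numbers stand for stronger inhibition and higher numbers for weaker inhibition), compound 1 (`NC1CCC(Nc2nc(NCc3ccc(-c4ccco4)cc3)c3ncn(C4CCCC4)c3n2)CC1`) gives 164 nM as the lower of two numbers, and compound 2 (`NC1CCC(Nc2nc(NCc3ccc(-c4ccsc4)cc3)c3ncn(C4CCCC4)c3n2)CC1`) gives 570 nM as the higher. Compound 3 (`CC(C)(O)CNc1nc(NCc2ccc(-c3ccco3)cc2)c2ncn(C3CCCC3)c2n1`) has 2-hydroxy-2-methylpropyl in place of 4-aminocyclohexyl on a nitrogen on an aromatic ring. Going by the values given here, the one measured step (a 3.5-fold higher number from compound 1 to compound 2 (0.54 log units; beyond the scatter)) puts thiophen-3-yl in place of furan-2-yl on an aromatic carbon, not on this nitrogen, so it offers only a rough yardstick of size. A larger step toward a higher number is expected here (a 12-fold higher number from compound 1 to compound 3 (1.09 log units; beyond the scatter)). Compound 3 is estimated at 2000 nM within a range from 600 nM to 7000 nM in this assay.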

Compound 3, half-maximal inhibitory concentration: 17400 nM
The estimate for compound 3 lay 8.7-fold (0.94 log units) below the measured number; measured number above the stated range.
By their numbers in this assay, from the lowest: compound 1; then compound 2; then compound 3.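

In this assay the group on this nitrogen proves far more decisive than the earlier change on the aromatic carbon: 2-hydroxy-2-methylpropyl in place of 4-aminocyclohexyl gives a 110-fold higher number from compound 1 to compound 3 (2.03 log units; beyond the scatter), whereas thiophen-3-yl in place of furan-2-yl gave only a 3.5-fold higher number from compound 1 to compound 2 (0.54 log units; beyond the scatter). Both groups on the nitrogen have the same hydrogen-bond donor and acceptor counts, so these counts do not distinguish them. Nothing available explains the size of this step.

From the compounds shown here alone, whether the ring or the amine matters more remains open: a 4-hydroxycyclohexyl group or an open-chain 2-aminoethyl group would separate the two. Also open, going by these compounds, is whether the step is the same size with thiophen-3-yl in place of furan-2-yl.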